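Sulfonyl substituent exchange from compound 1 to compound 4

This account rests on a few compounds, and the source may have more. Where it says the series, first, only, none or still open, it means among the compounds named here.

Compound 1 `Cn1c(=O)c(S(=O)(=O)Cc2ccc(F)cc2)cc2cnc(Nc3ccc4[nH]ccc4c3)nc21` is assessed in a functional assay on DU-145 cells (Homo sapiens) for inhibition, read by trypan blue exclusion, with a stated time of 72 h (a lower number here means a stronger inhibitor, a higher number a weaker inhibitor), where compound 1 gives 30000 nM. For the measured compounds named here, this is the highest of the three numbers measured so far. Compound 3 `Cn1c(=O)c(S(=O)(=O)c2ccc(Cl)cc2)cc2cnc(Nc3cnc4ccccc4c3)nc21` gives 15000 nM in this assay, a difference from compound 1 that sits within the scatter, while compound 2 `Cc1ccc(S(=O)(=O)c2cc3cnc(Nc4cccc5cccnc45)nc3n(C)c2=O)cc1` gives 10000 nM, a gap beyond the scatter. Compound 4 `Cn1c(=O)c(S(=O)(=O)c2ccc(F)cc2N)cc2cnc(Nc3ccc4[nH]ccc4c3)nc21` has not yet been measured. It differs from compound 1 in one place: 2-amino-4-fluorophenyl in place of 4-fluorobenzyl on a sulfonyl sulfur. Going by the values given here, no measured pair isolates this change, and the measured compounds vary in more than one place, so any comparison is loose. A modest step toward a lower number is expected, a 2.0-fold lower number from compound 1 to compound 4 (0.30 log units; within the scatter). Compound 4 is estimated at 15000 nM, with a range of 5000 nM to 45000 nM in this assay.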

Compound 4, half-maximal inhibitory concentration: 3000 nM
Estimate against measurement, compound 4: 5.0-fold (0.70 log units) above; the whole stated range lies above it.
By their numbers in this assay, from the lowest: compound 4; then compounds 2, 3 and 1 (each within the scatter of the next, the first and the last beyond it).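

In this assay, 2-amino-4-fluorophenyl in place of 4-fluorobenzyl on the sulfonyl sulfur gives a 10-fold lower number from compound 1 to compound 4 (1.00 log units; beyond the scatter), so the group at this position matters with the rest of compound 1 held constant. This single exchange combines two differences, an aryl group replacing a benzyl group and the addition of an amino group, and this pair cannot separate them. No available evidence bears on the reason for the step.

Open, as far as these compounds go, is whether plain 4-fluorophenyl on the sulfonyl sulfur retains the step. Also open, from the compounds shown here alone, is whether a hydroxyl group or a carboxylic acid can replace the amino group.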